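Exchanging chlorines on the sulfonyl aryl ring

The source may report more compounds than this note shows. Statements on the series, on what has been measured and on what is new or still open speak of the compounds shown alone.

For the measured compounds named here, compound 1 `COc1cc2nc(N3CCN(S(=O)(=O)c4ccc(Cl)cc4)CC3)nc(N)c2cc1OC` is one of two compounds measured in a functional assay on PC-3 cells (Homo sapiens) for inhibition (a lower number here means a stronger inhibitor, a higher number a weaker inhibitor), and compound 1 gives 23000 nM, the higher of the two numbers. Compound 2 `COc1cc2nc(N3CCN(S(=O)(=O)c4ccc(S(C)(=O)=O)cc4)CC3)nc(N)c2cc1OC` gives 17000 nM in this assay, and the step of a 1.4-fold lower number from compound 1 to compound 2 (0.13 log units; within the scatter) lies within the scatter. Compound 3 `COc1cc2nc(N3CCN(S(=O)(=O)c4cc(Cl)ccc4Cl)CC3)nc(N)c2cc1OC` differs from compound 1 in a single place: 2,5-dichlorophenyl in place of 4-chlorophenyl on a sulfonyl sulfur. Going by the values given here, no measured step replaces one chloro-substituted ring with another, so only the step from compound 1 to compound 2 offers any guide, and that one change on the same ring did not move the number beyond the scatter. Compound 3 is therefore expected to sit close to compound 1, with the step of a 1.2-fold lower number from compound 1 to compound 3 (0.06 log units; within the scatter) expected to stay within the scatter. Compound 3 is estimated at 20000 nM in this assay, with a range from 6000 nM to 60000 nM.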

Compound 3, half-maximal inhibitory concentration: 60000 nM
For compound 3 the middle estimate is 3.0-fold (0.48 log units) below the measured one, and the stated range covers the measured number.
By their numbers in this assay, from the lowest: compounds 2 and 1 (each within the scatter of the next); then compound 3.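

In this assay, for the compounds shown here, placing 2,5-dichlorophenyl on the sulfonyl sulfur in place of 4-chlorophenyl gives the first change at this position to pass the scatter, though only modestly (a 2.6-fold higher number from compound 1 to compound 3 (0.42 log units; beyond the scatter)). The same group in place of 4-(methylsulfonyl)phenyl gives a step of similar size (a 3.5-fold higher number from compound 2 to compound 3 (0.55 log units; beyond the scatter)), so compound 3 stands apart from compound 1 and compound 2, which lie within the scatter of each other. The number at this position therefore does respond to the aryl group on the sulfonyl sulfur, and here it moves towards weaker inhibition, though nothing available accounts for this shift. The compounds shown leave open whether one chlorine of the 2,5-dichlorophenyl group alone would carry the step or both are needed. They also leave open whether unsubstituted phenyl, benzyl or a phenyl ring bearing an amine or a carboxylic acid would lower the number.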